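Biaryl amide acids in a liver-cell cytotoxicity assay

The compounds below may be only part of what the source reports. "The series", "measured", "known", "first", "only" and "open" are said of these compounds alone.

Measured compounds:
compound 1 `CC(C)N(Cc1cccc(OCCCCCC(=O)O)c1)C(=O)c1ccc(-c2cccc(-c3ccccc3)c2)cc1` – > 26000 nM
compound 2 `CC(C)N(Cc1cccc(OCCCCCC(=O)O)c1)C(=O)c1ccc(-c2ccco2)cc1` – > 26000 nM
compound 3 `CC(C)N(Cc1cccc(OCCCCCC(=O)O)c1)C(=O)c1ccc(-c2cccc(Oc3ccccc3)c2)cc1` – > 18700 nM

All three compounds were tested in an ADME assay on HepG2 cells (Homo sapiens) for cytotoxicity, read by CellTiter-Glo and resazurin assay, with a stated time of 72 h; on this read-out lower numbers stand for an effect already at smaller amounts and higher numbers for an effect only at larger amounts of compound. In this assay compound 1 gives only a limit, > 26000 nM. Compound 2 likewise gives only a limit, > 26000 nM. Compound 3 gives a limit as well, > 18700 nM. Every value is a limit. The two one-place steps, a step that the two limits leave unreadable from compound 1 to compound 2 and a step that the two limits leave unreadable from compound 1 to compound 3, cannot be read in size or direction. Compound 2 therefore stands at the limit of > 26000 nM in this assay, at which 2 of the 3 values shown sit, while the third compound sits at the limit of > 18700 nM in this assay, at which 1 of the 3 values shown sits; nothing separates them beyond the fact that both are limits.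

The unmeasured compound 4 `CC(C)N(Cc1cccc(OCCCCCC(=O)O)c1)C(=O)c1ccc(-c2ccc3cc[nH]c3c2)cc1` differs from compound 2 in one place: 1H-indol-6-yl in place of furan-2-yl on an aromatic carbon. Among the measured compounds shown here, no measured step bears on this change with a readable size, since both steps from compound 1 are hidden behind the limits. For compound 4 the expected step is a number no higher from compound 2 to compound 4 (the limit leaves the size open), which is to say no change is expected beyond the scatter. Compound 4 is thus estimated to give 26000 nM in this assay, within a range from 13000 nM to 52000 nM, most probably again as a limit rather than a number.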

Compound 4, half-maximal effective concentration: > 26000 nM
Compound 4: a limit, no number; the forecaster's own chance of this, stated with the estimate: 80%; the middle value lies on the limit itself.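

Compound 4 gives only a limit in this assay, > 26000 nM. The steps to compound 4 from compound 1 and compound 2 cannot be read, since those two compounds also give only limits: the limit of > 26000 nM in this assay, at which 3 of the 4 values shown sit.

The compounds shown leave open at what concentration any of them reaches the half-maximal effect, and whether exchanging the group on the aromatic carbon changes it.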